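The compounds below may be only part of what the source reports. "The series", "measured", "known", "first", "only" and "open" are said of these compounds alone.

In a functional assay on A375P cells (Homo sapiens) for antiproliferative activity, read by MTT assay, with a stated time of 48 h (a higher number here means a weaker inhibitor, a lower number a stronger inhibitor), compound 1 `Nc1cccc2c(-c3cccc(NC(=O)c4ccc(Cl)c(C(F)(F)F)c4)c3)ccnc12` gives 1400 nM. Compound 2 `Nc1cccc2c(-c3cccc(NC(=O)c4cc(C(F)(F)F)cc(C(F)(F)F)c4)c3)ccnc12` gives 3400 nM in this assay, and compound 3 `Cc1ccc(NC(=O)c2ccc(Cl)c(C(F)(F)F)c2)cc1-c1ccnc2c(N)cccc12` gives 3300 nM. The change from compound 1 to compound 3 is methyl in place of hydrogen on an aromatic carbon and it brought a 2.4-fold higher number from compound 1 to compound 3 (0.37 log units; beyond the scatter). The difference between the core of compound 1 and the core of compound 2 is not broken down here.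

Compound 4 `Cc1ccc(NC(=O)c2cc(C(F)(F)F)cc(C(F)(F)F)c2)cc1-c1ccnc2c(N)cccc12` has not yet been measured in this assay. It differs from compound 2 by methyl in place of hydrogen on an aromatic carbon, the same kind of change as that from compound 1 to compound 3, though here the position is ortho to a 8-aminoquinolin-4-yl group rather than ortho to a large group. Since the earlier change gave a 2.4-fold higher number from compound 1 to compound 3 (0.37 log units; beyond the scatter), a step of about a 2.1-fold higher number from compound 2 to compound 4 (0.31 log units; beyond the scatter) is expected from compound 2 to compound 4. Compound 4 is therefore estimated at 7000 nM in this assay, likely between 3000 nM and 16000 nM.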

Compound 4, half-maximal inhibitory concentration: 7400 nM
Beside the measured number, compound 4's estimate is 1.1-fold (0.02 log units) below it, within the range that was stated.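

Placing methyl on the aromatic carbon ortho to a 8-aminoquinolin-4-yl group brought a 2.2-fold higher number from compound 2 to compound 4 (0.34 log units; beyond the scatter) in this assay. Within the data shown here, the change thus carried over from one core to the other with much the same size, and both compounds with the methyl were the weaker member of their pair: the same change on two cores in this assay, a 2.4-fold higher number (0.37 log units; beyond the scatter) from compound 1 to compound 3 and a 2.2-fold higher number (0.34 log units; beyond the scatter) from compound 2 to compound 4, 1.1-fold (0.03 log units) apart, within the scatter of two such steps This rests on only two pairs in a single cell assay, so it does not show that the step would hold on other cores, and it does not show why the methyl has this effect.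

The compounds shown leave open whether an ethyl or methoxy group in the same place would give a step of similar size. They also leave open how an amine or a carboxylic acid in place of a trifluoromethyl group would behave.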